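The source may report more compounds than this note shows. Statements on the series, on what has been measured and on what is new or still open speak of the compounds shown alone.

Series notes, inhibition read-out. In a functional assay (Homo sapiens) for inhibition of Nucleic Acid, tested at 100 uM (on this read-out higher numbers stand for more inhibition at the one concentration tested (going by the name of the read-out) and lower numbers for less inhibition), compound 1 `c1ccc(CNc2[nH]ccc3ncnc2-3)cc1` gives 75%, compound 2 `OCCNc1[nH]ccc2ncnc1-2` gives 3% and compound 3 `Nc1nccc2c1ncn2[C@H]1C[C@H](O)[C@@H](CO)O1` gives 18%. Compound 3 thus stands second of the three numbers: its nearest neighbour is compound 2, whose value lies lower by a margin beyond the scatter, while compound 1 lies far above it, also beyond the scatter.

Compound 4 `CSc1nccc2c1ncn2[C@H]1C[C@H](O)[C@@H](CO)O1` differs from compound 3 in one place: methylsulfanyl in place of amino on an aromatic carbon. For the measured compounds named here, no measured pair with this change is available, so the size of the step rests on judgement only. A small step, downward or none beyond the scatter, is expected, since only compound 3 with 18% anchors it. Compound 4 is estimated at 12%, between -10% and 40%, an expected step of a number 6 percentage points lower from compound 3 to compound 4 (within the scatter).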

Compound 4, a percentage reported as inhibition, at one concentration (the size of the read-out at that concentration, not a potency): 36%
Compound 4: middle estimate off by 24 percentage points, on the low side; the measured number falls inside the stated range.
By their numbers in this assay, from the lowest: compound 2; then compound 3; then compound 4; then compound 1.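

At this aromatic carbon next to the ring nitrogen, methylsulfanyl in place of amino gives a number 18 percentage points higher from compound 3 to compound 4 (beyond the scatter) in this assay. For the compounds shown here, this is the first single-place step, and it shows that inhibition at this read-out does not depend on the amino group or its hydrogen-bond donor, since compound 4 has none at this place. Nothing measured here accounts for the step.

Still open, going by these compounds, is whether a longer chain on the sulfur, such as ethylsulfanyl or benzylsulfanyl, goes further in the same direction. Also open, on these data alone, is whether a methoxy group or a chlorine on this carbon behaves like methylsulfanyl.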